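Chloro in place of piperazin-1-yl: a small expected loss

The compounds below may be only part of what the source reports. "The series", "measured", "known", "first", "only" and "open" are said of these compounds alone.

Of the compounds shown here, three sharing one core have been measured in a functional assay on MDA-MB-231 cells (Homo sapiens) for inhibition, read by MTT assay, with a stated time of 72 h (a lower number here means a stronger inhibitor, a higher number a weaker inhibitor), so far. Compound 1 (`CC(C)(C)n1cc2c(n1)C(=O)CC1(CCN(C(=O)c3cc(-c4ccccc4Cl)nc4ccccc34)CC1)O2`), carrying 2-chlorophenyl, stands at > 10000 nM as a limit of the assay and not a number. Compound 2 (`COc1ccc(-c2cc(C(=O)N3CCC4(CC3)CC(=O)c3nn(C(C)(C)C)cc3O4)c3ccccc3n2)cc1OC`), carrying 3,4-dimethoxyphenyl, gives 7130 nM in this test, and compound 3 (`CC(C)(C)n1cc2c(n1)C(=O)CC1(CCN(C(=O)c3cc(N4CCNCC4)nc4ccccc34)CC1)O2`), carrying piperazin-1-yl, gives 4200 nM in the same test. Compound 3 therefore stands level with compound 2, given the gap of a 1.7-fold lower number from compound 2 to compound 3 (0.23 log units; within the scatter) between them, and clear of the limit, given the gap of an at least 2.3-fold lower number from compound 1 to compound 3 (0.37 log units; beyond the scatter) on that side.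

Compound 4 (`CC(C)(C)n1cc2c(n1)C(=O)CC1(CCN(C(=O)c3cc(Cl)nc4ccccc34)CC1)O2`) differs from compound 3 by chloro in place of piperazin-1-yl on an aromatic carbon at the same spot, next to the ring nitrogen. Both measured steps bear on it when read backwards, since each brings piperazin-1-yl in. One is within the scatter, and the other is a floor just beyond it. Neither group that leaves in those steps is chloro, so they are only a loose guide. The expected change is a 2.1-fold higher number from compound 3 to compound 4 (0.33 log units; beyond the scatter) in this assay as a modest move towards weaker inhibition. For compound 4 the estimate is 9000 nM within an expected range of 4000 nM to 20000 nM in this test.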

Compound 4, half-maximal inhibitory concentration: 9220 nM
Beside the measured number, compound 4's estimate is 1.0-fold (0.01 log units) below it, within the range that was stated.
By their numbers in this assay, from the lowest: compounds 3, 2 and 4 (each within the scatter of the next, the first and the last beyond it). At a limit, above all of these: compound 1.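

In this assay, swapping the piperazin-1-yl ring for a single chlorine atom gives a 2.2-fold higher number from compound 3 to compound 4 (0.34 log units; beyond the scatter), so this position does respond to the change, though only modestly. Chloro in place of 3,4-dimethoxyphenyl gives a 1.3-fold higher number from compound 2 to compound 4 (0.11 log units; within the scatter), so these two groups cannot be told apart at this position, even though chloro brings no ring at all. Chloro in place of 2-chlorophenyl gives an at least 1.0-fold lower number from compound 1 to compound 4 (0.03 log units; that floor lies within the scatter). That step cannot be read as a size, because compound 1 stands at a limit of the assay and not at a number: the limit of > 10000 nM in this assay, at which 1 of the 4 values shown sits.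

The compounds shown do not reveal whether the modest advantage of compound 3 over compound 4 depends on the whole piperazine ring or simply on having an amine nitrogen at this carbon, a question that a small open-chain amine such as dimethylamino, or a morpholin-4-yl ring with oxygen in place of the second nitrogen, would help to settle. They also leave open how a plain hydrogen at this position would compare with chloro.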